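The source may report more compounds than this note shows. Statements on the series, on what has been measured and on what is new or still open speak of the compounds shown alone.

Of the compounds shown here, three have been measured in a functional assay on DU-145 cells (Homo sapiens) for cytotoxicity, read by sulforhodamine B assay, with a stated time of 48 h; on this read-out higher numbers stand for weaker inhibition of growth and lower numbers for stronger inhibition of growth. Compound 1 `ClCc1ccc(Cn2cnc3c(Cl)ncnc32)cc1` gives 1310 nM. Compound 3 `ClCc1ccc(Cn2cnc3c(Cl)nc(Cl)nc32)cc1` gives 5620 nM in this assay. Compound 3 differs from compound 1 by one change, (chloro in place of hydrogen on an aromatic carbon), and that change gave a 4.3-fold higher number from compound 1 to compound 3 (0.63 log units; beyond the scatter). Compound 2 `ClCc1cccc(Cn2cnc3ncnc(Cl)c32)c1` gives 15100 nM in this assay, the highest of the three numbers; the difference between the cores of compound 2 and compound 1 is not broken down here. Compound 4 `ClCc1cccc(Cn2cnc3nc(Cl)nc(Cl)c32)c1` has not yet been measured. It differs from compound 2 by chloro in place of hydrogen on an aromatic carbon, the same change that turns compound 1 into compound 3, with its surroundings described in the same words; among the compounds shown this change occurs in two pairs. In this assay the expected step is a 3.3-fold higher number from compound 2 to compound 4 (0.52 log units; beyond the scatter), resting on the earlier step of a 4.3-fold higher number from compound 1 to compound 3 (0.63 log units; beyond the scatter) and kept somewhat smaller only because compound 2 starts from 15100 nM. Compound 4 is therefore estimated at 50000 nM, with a range expected from 15000 nM to 150000 nM.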

Compound 4, concentration for 50% growth inhibition: 140 nM
Compound 4: middle estimate off by 360-fold (2.55 log units), on the high side; the measured number lies below the stated range.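

Chloro in place of hydrogen on the aromatic carbon between two ring nitrogen atoms gave a 110-fold lower number from compound 2 to compound 4 (2.03 log units; beyond the scatter), which runs opposite to the earlier step on the other core: the same change on two cores in this assay, a 4.3-fold higher number (0.63 log units; beyond the scatter) from compound 1 to compound 3 and a 110-fold lower number (2.03 log units; beyond the scatter) from compound 2 to compound 4, 460-fold (2.67 log units) apart, beyond the scatter of two such steps

In these two pairs, then, the same change does not carry from one core to the other, neither in size nor in direction, and the step seen with compound 1 and compound 3 gave no safe guide to the step from compound 2. What this does not show is which structural difference is responsible: compound 1 and compound 2 differ in more than one place, and two pairs cannot separate those differences or give a reason for the reversal.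

On these data alone, it remains open whether an amine or a methoxy group on that same carbon would also behave differently on the two cores. As far as these compounds go, it is equally open whether compound 4 would keep its low number if a longer chain replaced its chloromethyl group.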